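Nitrooxy step in a paw edema series

A few compounds are considered here, and "the series" means these few. Any claim that something is new, unique, unknown or untested is made for them only; others in the source may bear on it.

Measured compounds and read-outs:
compound 1 `Cc1nc2ccccc2c(=O)n1NC(=O)NC1CCCCC1`, 88.6%
compound 2 `CC(=O)Nc1ccc(S(=O)(=O)Nn2c(C)nc3ccccc3c2=O)cc1`, 95.7%
compound 3 `O=C(NC1CCCCC1)Nn1c(CO[N+](=O)[O-])nc2ccccc2c1=O`, 80.6%

All three numbers come from a functional assay on the whole organism (strain Sprague-Dawley) for inhibition, with Rattus norvegicus as the target, read by paw edema, with stated times of 30 min and 3 h, at a dose of 80 mg/kg by the oral route; on this read-out lower numbers stand for less inhibition and higher numbers for more inhibition at the one dose given (going by the name of the read-out). Compound 3 is obtained from compound 1 by one change, (nitrooxy in place of hydrogen on a saturated chain carbon bound to an aromatic carbon), and the step that this change made is a number 8 percentage points lower from compound 1 to compound 3 (within the scatter). Compound 2 carries a different core from compound 1; the difference between the two cores is not broken down here. The number for compound 2 lies within the scatter of the number for compound 1 and beyond the scatter of the number for compound 3.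

Within the data shown here, compound 4 `CC(=O)Nc1ccc(S(=O)(=O)Nn2c(CO[N+](=O)[O-])nc3ccccc3c2=O)cc1` is obtained from compound 2 by nitrooxy in place of hydrogen on a saturated chain carbon bound to an aromatic carbon, the same change at the same place as the one that led from compound 1 to compound 3. In this assay, among the measured compounds shown here, the step from compound 2 to compound 4 is expected to be a number 6.7 percentage points lower from compound 2 to compound 4 (within the scatter), which rests on the one measured instance, a number 8 percentage points lower from compound 1 to compound 3 (within the scatter), and on the fact that the number for compound 2 is already high. Compound 4 is therefore estimated at 89%, with a likely range from 79% to 98%.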

Compound 4, a percentage reported as inhibition, in the whole organism at one dose (the size of the read-out at that dose, not a potency): > 100%
Compound 4: no number, only a limit; the forecaster's own chance of this, stated with the estimate: 0%; middle value at least 11 percentage points away from the limit.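

Compound 4 reads > 100% in this assay, and this is a limit of the assay, not a number. On the core of compound 2, nitrooxy in place of hydrogen gives a number at least 4.3 percentage points higher from compound 2 to compound 4 (that floor lies within the scatter), and set beside the earlier step on the core of compound 1 it reads: the same change on two cores in this assay, a number 8 percentage points lower (within the scatter) from compound 1 to compound 3 and a number at least 4.3 percentage points higher (that floor lies within the scatter) from compound 2 to compound 4; the limit leaves it open whether they differ. Across these two cores, the change brings no fall beyond the scatter, but this does not show that its step is the same on both or that it would hold on any other core, and the reading of compound 4 cannot settle the size of its step: the limit of > 100% in this assay, at which 1 of the 4 values shown sits.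

The compounds shown leave open how the change behaves on a third core, since only two pairs carry it. They also leave open how an amine or a carboxylic acid would compare with nitrooxy on a saturated chain carbon bound to an aromatic carbon.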